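Methyl to Ethyl: Expecting Little Change in Inhibition

The source may report more compounds than this note shows. Statements on the series, on what has been measured and on what is new or still open speak of the compounds shown alone.

Compound 1, `CCc1ccc(S(=O)(=O)NC(=O)Nc2ccc(Cl)cc2)[nH]1`: 56%
Compound 2, `Cc1ccsc1S(=O)(=O)NC(=O)Nc1ccc(Cl)cc1`: 62%

In a functional assay on the whole organism (6C3HED cells, Mus musculus) for inhibition, at a dose of 300 mg/kg by the oral route (a higher number here means more inhibition at the dose given (going by the name of the read-out), a lower number less inhibition), compound 2 gives 62%, and compound 1 gives a value that lies within the usual scatter of that number, so the two cannot be told apart. Among the compounds with values here, the only measured step, a number 6 percentage points higher from compound 1 to compound 2 (within the scatter), exchanges one whole ring for another and stays within the scatter. Compound 3, `CCc1ccsc1S(=O)(=O)NC(=O)Nc1ccc(Cl)cc1`, differs from compound 2 by methyl in place of hydrogen on a saturated chain carbon bound to an aromatic carbon. Within the data shown here, no measured step tests this kind of small extension of a chain, so there is no direct guide. Given that even the larger ring swap moved the read-out by only a number 6 percentage points higher from compound 1 to compound 2 (within the scatter), the step from compound 2 to compound 3 is expected to be a number 2 percentage points lower from compound 2 to compound 3 (within the scatter), that is, nothing beyond the scatter. Compound 3 is therefore estimated at 60%, with a likely range from 40% to 80%.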

Compound 3, a percentage reported as inhibition, in the whole organism at one dose (the size of the read-out at that dose, not a potency): 25%
Estimate against measurement, compound 3: 35 percentage points above; the measured number lies below the stated range.
By their numbers in this assay, from the lowest: compound 3; then compounds 1 and 2 (each within the scatter of the next).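

Extending 3-methylthiophen-2-yl to 3-ethylthiophen-2-yl adds only one carbon, yet in this assay it gives a number 37 percentage points lower from compound 2 to compound 3 (beyond the scatter), so this position responds strongly to a very small change, which the earlier ring exchange, within the scatter, gave no sign of. The exchange of 5-ethyl-1H-pyrrol-2-yl for 3-ethylthiophen-2-yl now also gives a number 31 percentage points lower from compound 1 to compound 3 (beyond the scatter), so swapping these groups on the sulfonyl sulfur is not harmless in every case. Nothing available explains why the extra methyl lowers the number.

The compounds shown leave open whether a longer chain, such as propyl, would lower the inhibition further or whether the loss stops at ethyl. They also leave open how a methoxy group at this position would compare with methyl and ethyl.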